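Sulfonamide nitrogen demethylation in the PLK2 series

The compounds below may be only part of what the source reports. "The series", "measured", "known", "first", "only" and "open" are said of these compounds alone.

Compound 1 `CCC1C(=O)N(C)c2cnc(Nc3ccc(S(=O)(=O)NC)cc3)nc2N1c1ccn(C)n1` is the reference point for this step. In an assay for inhibition of serine/threonine-protein kinase PLK2 (Homo sapiens), read by FRET and Z'-LYTE, with a stated time of 1 h (on this read-out higher numbers stand for weaker inhibition and lower numbers for stronger inhibition), compound 1 gives 71.6 nM. Among the three numbers known so far this stands second highest. Compound 2 `CCC1C(=O)N(C)c2cnc(-n3ccc4cc(C(=O)NC)ccc43)nc2N1c1ccn(C)n1` gives 218 nM, a higher number than compound 1 and beyond the scatter. Compound 3 `CC[C@@H]1C(=O)N(C)c2cnc(Nc3ccc(S(=O)(=O)NCCCO)cc3)nc2N1C1CCCC1` gives 8.16 nM, a lower number than compound 1, also beyond the scatter. Within the data shown here, compound 3 differs from compound 1 in more than one place, and compound 2 likewise, so none of the measured pairs isolates a single structural change.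

Compound 4 `CCC1C(=O)N(C)c2cnc(Nc3ccc(S(N)(=O)=O)cc3)nc2N1c1ccn(C)n1` has not been measured. It differs from compound 1 by hydrogen in place of methyl on a sulfonamide nitrogen. Among the measured compounds shown here, no measured pair in the set shows this change on its own, so the expectation rests on the spread of the set rather than on a known step. The step of a 1.1-fold lower number from compound 1 to compound 4 (0.04 log units; within the scatter) is expected to stay within the usual scatter, with no direction claimed. Compound 4 is accordingly estimated at 65 nM, with a range from 25 nM to 170 nM.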

Compound 4, half-maximal inhibitory concentration: 121 nM
Estimate against measurement, compound 4: 1.9-fold (0.27 log units) below; the measured number falls inside the stated range.
By their numbers in this assay, from the lowest: compound 3; then compounds 1, 4 and 2 (each within the scatter of the next, the first and the last beyond it).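

Among these compounds, the first single-place step falls on the sulfonamide nitrogen: hydrogen in place of methyl gives a 1.7-fold higher number from compound 1 to compound 4 (0.23 log units; within the scatter) in this assay and so stays inside the usual scatter. On the core of compound 1, then, the methyl on this nitrogen can be exchanged for hydrogen with no measurable consequence, so the methylsulfamoyl and sulfamoyl forms cannot be told apart in this assay. No measured information bears on why this position responds so little.

Still open, as far as these compounds go, is whether larger groups on the same sulfonamide nitrogen, such as an ethyl group, a longer chain ending in an amine or one ending in a carboxylic acid, would also leave the number within the scatter. The compounds shown also leave open whether the same exchange behaves alike on another core.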